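This account rests on a few compounds, and the source may have more. Where it says the series, first, only, none or still open, it means among the compounds named here.

Compound 1 `Nc1cc(N)c2nc(-c3ccccc3)c(NCc3ccc(Cl)c(Cl)c3)nc2c1` was tested in a functional assay on SF-268 cells (Homo sapiens) for inhibition, read by sulforhodamine B assay, with a stated time of 48 h; a higher number here means that more compound is tolerated, a lower number that less compound is tolerated. There compound 1 gives < 100000 nM, which is a limit of the assay rather than a measured number. Compound 2 `CCOC(=O)[C@H](CCC(=O)O)NC(=O)c1ccc(Oc2nc3cc(N)cc(N)c3nc2-c2ccccc2)cc1` shares the same core and was measured the same way. In this assay compound 2 gives < 100000 nM, again only a limit. Compound 1 therefore stands at the limit, and the numbers available do not place it above or below any other compound (the limit of < 100000 nM in this assay, at which 2 of the 2 values shown sit). Within the data shown here, no step between two measured compounds can be drawn from this. Compound 3 `COc1ccc(CNc2nc3cc(N)cc(N)c3nc2-c2ccccc2)cc1` is not yet measured; it differs from compound 1 by 4-methoxyphenyl in place of 3,4-dichlorophenyl on a saturated chain carbon bound to a nitrogen on an aromatic ring. In this assay no change beyond the scatter is expected, and the step that the limit leaves unreadable from compound 1 to compound 3 is an estimate only. Compound 3 is expected to give about 50000 nM, within a range from 10000 nM to 100000 nM, and most likely the assay will again report only a limit.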

Compound 3, concentration lethal to 50% of the cells: 49000 nM
Compound 3: the middle estimate sits 1.0-fold (0.01 log units) above what was measured, within the range that was stated.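

Among these compounds, no step from compound 1 to compound 3 can be read in this assay, as the result for compound 1 is only a limit: the limit of < 100000 nM in this assay, at which 2 of the 3 values shown sit. The compounds shown leave open what 4-methoxyphenyl in place of 3,4-dichlorophenyl does to the concentration the cells tolerate.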